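This account rests on a few compounds, and the source may have more. Where it says the series, first, only, none or still open, it means among the compounds named here.

The measured compounds:
Compound 1, `Nc1nc(-c2cccc(CO)c2)nc2sc(-c3ccco3)nc12`, with 0.9 nM.
Compound 2, `Nc1nc(-c2ccc(CO)cc2)nc2sc(-c3ccco3)nc12`, with 3.58 nM.
Compound 3, `COc1ccc(-c2nc(N)c3nc(-c4ccco4)sc3n2)cc1`, with 4.66 nM.

All three were tested in an assay on CHO cells for displacement of a labelled ligand from adenosine receptor A3 (Homo sapiens), read by scintillation counting, with a stated time of 3 h; a lower number here means a stronger inhibitor, a higher number a weaker inhibitor. Compound 1 gives the lowest number of the three; its nearest neighbour is compound 2, and that gap is beyond the scatter. How the core of compound 1 and the core of compound 2 differ is not broken down here. Compound 2 and compound 3 differ in one place only: methoxy in place of hydroxymethyl on an aromatic carbon. That change moved the number by a 1.3-fold higher number from compound 2 to compound 3 (0.11 log units; within the scatter), a step within the scatter, so the two cannot be ranked against each other.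

The unmeasured compound 4, `COc1cccc(-c2nc(N)c3nc(-c4ccco4)sc3n2)c1`, is related to compound 1 by the same kind of change: methoxy in place of hydroxymethyl on an aromatic carbon. The surroundings differ in one respect: in compound 1 the group sits meta to a large group, whereas in compound 2 it sits para to a large group. In this assay, going by the values given here, the step expected from compound 1 is a 1.3-fold higher number from compound 1 to compound 4 (0.12 log units; within the scatter), resting on the single earlier example a 1.3-fold higher number from compound 2 to compound 3 (0.11 log units; within the scatter). Compound 4 is therefore estimated at 1.2 nM, with a likely range of 0.5 nM to 3 nM.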

Compound 4, inhibition constant: 4.9 nM
Compound 4: middle estimate off by 4.1-fold (0.61 log units), on the low side; the whole stated range lies below it.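

In this assay, putting methoxy in place of hydroxymethyl gave a 5.4-fold higher number from compound 1 to compound 4 (0.74 log units; beyond the scatter), so a change that could not be read on one core made a clear difference on the other. The size of this step therefore does not carry reliably from one core to another in this series, as the two examples disagree: the same change on two cores in this assay, a 1.3-fold higher number (0.11 log units; within the scatter) from compound 2 to compound 3 and a 5.4-fold higher number (0.74 log units; beyond the scatter) from compound 1 to compound 4, 4.2-fold (0.62 log units) apart, beyond the scatter of two such steps

This does not show why they differ: the group sits meta to a large group in compound 4, and its position differs in the other pair, but two pairs cannot tell whether position is the cause or give a rule for predicting other cores.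

Only hydroxymethyl and methoxy appear at this place in the compounds shown, so it remains open how an amine, a carboxylic acid or a longer chain would read there on either core. As far as these compounds go, it also remains open whether the same change would give a small or a large step on a third core.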